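The compounds below may be only part of what the source reports. "The series", "measured", "known", "first", "only" and "open" are said of these compounds alone.

Working notes on the series.

Compound 1 `CS(=O)(=O)Nc1cccc2c1CCC2c1ncc[nH]1` carries a methanesulfonamido group on the core. In a functional assay on CHO cells for agonist activity at Alpha-1A adrenergic receptor (Homo sapiens), read by FLIPR and calcium flux (on this read-out higher numbers stand for an effect only at larger amounts of compound and lower numbers for an effect already at smaller amounts), compound 1 gives 70 nM, the highest number of the three measured compounds. Compound 2 `c1cc(-c2cn[nH]c2)c2c(c1)C(c1ncc[nH]1)CC2` gives 14 nM in this assay, and compound 3 `Cc1n[nH]cc1-c1cccc2c1CCC2c1ncc[nH]1` gives 3 nM. The two measured steps away from compound 1 both point the same way: a 5.0-fold lower number from compound 1 to compound 2 (0.70 log units; beyond the scatter), and a 23-fold lower number from compound 1 to compound 3 (1.37 log units; beyond the scatter). Within the pyrazole pair, a 4.7-fold lower number from compound 2 to compound 3 (0.67 log units; beyond the scatter).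

Compound 4 `Cn1ccc(-c2cccc3c2CCC3c2ncc[nH]2)n1` is the next step from compound 1: 1-methyl-1H-pyrazol-3-yl in place of methanesulfonamido on an aromatic carbon. The change places a five-membered aromatic ring with two hetero atoms where the methanesulfonamido group stood, as in compounds 2 and 3, so those steps bear on it. The entering group carries no hydrogen-bond donor and sits on the ring through a different atom than the 1H-pyrazol-4-yl groups of compounds 2 and 3, so the size of the effect is less certain. A modest lowering of the number, near the step from compound 1 to compound 2, is expected rather than the larger one seen for compound 3; the expected step is a 3.9-fold lower number from compound 1 to compound 4 (0.59 log units; beyond the scatter). Compound 4 is estimated at 18 nM, with a range from 5 nM to 70 nM.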

Compound 4, half-maximal effective concentration: > 1300 nM
Compound 4 ended at the assay's limit; the forecaster's own chance of this, stated with the estimate: 3%; middle value at least 72-fold (1.85 log units) from the limit.
By their numbers in this assay, from the lowest: compound 3; then compound 2; then compound 1. At a limit, above all of these: compound 4.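

In this assay compound 4 gives > 1300 nM, which is a limit of the assay and not a number: the limit of > 1300 nM in this assay, at which 1 of the 4 values shown sits. This position on an aromatic carbon of the shared core therefore does not accept every five-membered aromatic ring with 2 hetero atoms in place of methanesulfonamido: the replacement lowered the number in compounds 2 and 3, whereas here the direction reverses, with an at least 18-fold higher number from compound 1 to compound 4 (1.26 log units; beyond the scatter). Among these compounds, the choice of pyrazole group carries more weight than the earlier compounds showed, since the steps between pyrazoles are wide, with an at least 92-fold higher number from compound 2 to compound 4 (1.96 log units; beyond the scatter) and an at least 430-fold higher number from compound 3 to compound 4 (2.63 log units; beyond the scatter), against the modest methyl step within the pair of compounds 2 and 3.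

The entering group of compound 4 differs from the 1H-pyrazol-4-yl group of compound 2 both in its methyl and in the ring atom through which it is attached, and the compounds shown do not separate these two changes. From the compounds shown here alone, a 1-methyl-1H-pyrazol-4-yl or a 1H-pyrazol-3-yl group on the same aromatic carbon would bear on that question, and how an amine or a carboxylic acid behaves at this position remains open.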